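A Methoxyphenyl Variant of Compound 1

This account rests on a few compounds, and the source may have more. Where it says the series, first, only, none or still open, it means among the compounds named here.

Compound 1 `COC(=O)c1cc(-n2cc(-c3cccc(O)c3)nn2)ccc1O`: 6%
Compound 2 `O=C(OCCCc1ccccc1)c1cc(-n2cc(-c3cccc(O)c3)nn2)ccc1O`: 11%
Compound 3 `O=C(OCCCc1ccccc1)c1cc(-n2cc(-c3cc(O)ccc3O)nn2)ccc1O`: 39%

In a functional assay on HCT-116 cells (Homo sapiens) for inhibition, read by MTT assay, with a stated time of 2 days, tested at 10 uM (on this read-out lower numbers stand for less inhibition and higher numbers for more inhibition at the one concentration tested (going by the name of the read-out)), compound 1 gives 6%, the lowest of the three numbers, though compound 2 lies within the scatter of it; only compound 3 stands beyond it. Compound 4 `COC(=O)c1cc(-n2cc(-c3ccccc3OC)nn2)ccc1O` differs from compound 1 in one place: 2-methoxyphenyl in place of 3-hydroxyphenyl on an aromatic carbon. Among the measured compounds shown here, one measured step touches the aryl group on that carbon, a number 28 percentage points higher from compound 2 to compound 3 (beyond the scatter), where a hydroxy entered and the number rose. Here the group that leaves carries a hydroxy and the group that enters carries none. The step of a number 5 percentage points higher from compound 1 to compound 2 (within the scatter) concerns the ester and does not bear on this change. Since compound 1 already sits low, compound 4 is expected to stay close to it, with no change at the digits printed from compound 1 to compound 4 (within the scatter). The estimate for compound 4 is 6%, ranging from 0% to 20%.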

Compound 4, a percentage reported as inhibition, at one concentration (the size of the read-out at that concentration, not a potency): 8%
Estimate against measurement, compound 4: 2 percentage points below; the measured number falls inside the stated range.
By their numbers in this assay, from the lowest: compounds 1, 4 and 2 (each within the scatter of the next); then compound 3.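

In this assay, 2-methoxyphenyl in place of 3-hydroxyphenyl gives a number 2 percentage points higher from compound 1 to compound 4 (within the scatter), so on the methyl ester this aryl position accepts a group with no hydrogen-bond donor without a reading separable from that of compound 1. The earlier step at this aryl group, a number 28 percentage points higher from compound 2 to compound 3 (beyond the scatter), added a hydroxy on the longer ester, whereas this change removes one on the methyl ester. No supporting data here account for either outcome.

Going by these compounds, how 2-methoxyphenyl would read on the ester of compound 2 remains open. So does the effect of an amine or a carboxylic acid on this aryl ring.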